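Rearranging two fluorines on the benzyl arm of compound 3

The compounds below may be only part of what the source reports. "The series", "measured", "known", "first", "only" and "open" are said of these compounds alone.

Measured in an assay on FRT cells for positive allosteric modulation of Cystic fibrosis transmembrane conductance regulator variant N1303K (Homo sapiens), in the presence of a further agent that is not named here; a lower number here means that less compound is needed, a higher number that more compound is needed for the effect:
compound 1 `COc1ccc2[nH]c3c(c2c1)CCNC31CCN(Cc2cc(Cl)ccc2[N+](=O)[O-])CC1` gives 7100 nM;
compound 2 `COc1ccc2[nH]c3c(c2c1)CCNC31CCN(Cc2ccc(Br)c(F)c2)CC1` gives 1800 nM;
compound 3 `COc1ccc2[nH]c3c(c2c1)CCNC31CCN(Cc2ccc(F)cc2F)CC1` gives 2000 nM.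

Compound 3 stands second highest of the three numbers. Its nearest neighbour is compound 2, and that gap, a 1.1-fold higher number from compound 2 to compound 3 (0.05 log units; within the scatter), lies within the scatter, so the two cannot be put in order. The only differences beyond the scatter lead away from compound 1: a 3.6-fold lower number from compound 1 to compound 3 (0.55 log units; beyond the scatter), and in the same way a 3.9-fold lower number from compound 1 to compound 2 (0.60 log units; beyond the scatter).

Compound 4 `COc1ccc2[nH]c3c(c2c1)CCNC31CCN(Cc2cccc(F)c2F)CC1` differs from compound 3 by 2,3-difluorophenyl in place of 2,4-difluorophenyl on a saturated chain carbon bound to an amine nitrogen in a ring. For the measured compounds named here, of the measured steps, only the one between compound 2 and compound 3 concerns an exchange of one halogen-bearing phenyl for another, and it was a 1.1-fold higher number from compound 2 to compound 3 (0.05 log units; within the scatter), inside the scatter. The two larger steps both involve leaving the 5-chloro-2-nitrophenyl of compound 1, a group that is not touched here. The expectation for compound 4 in this assay is therefore no step beyond the scatter: no change at the digits printed from compound 3 to compound 4 (within the scatter). Compound 4 is estimated at 2000 nM, with a range from 800 nM to 5000 nM.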

Compound 4, half-maximal effective concentration: 13600 nM
The estimate for compound 4 lay 6.8-fold (0.83 log units) below the measured number; the measured number lies above the stated range.
By their numbers in this assay, from the lowest: compounds 2 and 3 (each within the scatter of the next); then compounds 1 and 4 (each within the scatter of the next).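

Within this assay, the same atoms arranged differently on the phenyl ring give a 6.8-fold higher number from compound 3 to compound 4 (0.83 log units; beyond the scatter), so at this position the placement of the two fluorines matters, not only which atoms are present. The comparison with the bromo-fluoro arm is of similar size, a 7.6-fold higher number from compound 2 to compound 4 (0.88 log units; beyond the scatter), which sets the 2,3-difluorobenzyl arm apart from both the 2,4-difluorobenzyl arm and the 4-bromo-3-fluorophenyl arm. By contrast, a 1.9-fold higher number from compound 1 to compound 4 (0.28 log units; within the scatter) lies within the scatter, so compound 4 and compound 1 cannot be put in order, and leaving the 5-chloro-2-nitrophenyl group does not by itself bring a lower number; no measurement at hand accounts for the effect of moving the fluorine.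

The compounds shown leave open whether a single fluorine on the phenyl ring, or a plain benzyl with no halogen at all, would sit nearer compound 3 or nearer compound 4. Going by these compounds, how a phenyl bearing a nitrile or a methoxy group would behave on this arm also remains open, as does whether the same sensitivity to fluorine placement would hold with a different group on the shared core.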